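This account rests on a few compounds, and the source may have more. Where it says the series, first, only, none or still open, it means among the compounds named here.

Values in an ADME assay on microsomes from liver (Mus musculus, strain CD-1) for metabolic stability, read by LC-MS, tested at 2 uM (a higher number here means that the compound lasts longer, a lower number that the compound disappears faster), so far

Compound 1 `Cn1ccc2ccc(-c3cc(Nc4ccccc4S(=O)(=O)N4CCOCC4)cc4nccnc34)cc21` gives 0.367 h
Compound 2 `CN1CCC(NC(=O)c2ccncc2Nc2cc(-c3ccc4ccn(C)c4c3)c3nccnc3c2)CC1` gives > 1 h (a limit of the assay, not a number)
Compound 3 `CN1CC(NC(=O)c2ccncc2Nc2cc(-c3ccc4ccn(C)c4c3)c3nccnc3c2)CCC1=O` gives 0.75 h

Of the two true numbers, compound 1 gives 0.367 h and compound 3 gives 0.75 h, so compound 3 stands the higher of the two and the gap lies beyond the scatter. Compound 4 `CN1CCC(N(C)C(=O)c2ccncc2Nc2cc(-c3ccc4ccn(C)c4c3)c3nccnc3c2)C1` carries methyl(1-methylpyrrolidin-3-yl)amino in place of (1-methyl-6-oxopiperidin-3-yl)amino on a carbonyl carbon and is not yet measured. Among the measured compounds shown here, the one measured step on this amide group is an at least 1.3-fold lower number from compound 2 to compound 3 (0.12 log units; that floor lies within the scatter) and it offers only a floor within the scatter. Resting on that step, no change beyond the scatter is expected in this assay and the estimated step runs a 1.1-fold lower number from compound 3 to compound 4 (0.03 log units; within the scatter) for now. For compound 4 the expected half-life is 0.7 h with an estimated range of 0.3 h to 1.4 h as the working figure.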

Compound 4, half-life: > 1 h
Compound 4 ended at the assay's limit (the forecaster's own chance of this, stated with the estimate: 25%); middle value at least 1.4-fold (0.15 log units) from the limit.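

In this assay, replacing (1-methyl-6-oxopiperidin-3-yl)amino on the carbonyl carbon with methyl(1-methylpyrrolidin-3-yl)amino gives an at least 1.3-fold higher number from compound 3 to compound 4 (0.12 log units; that floor lies within the scatter). Compound 2 and compound 4 carry different amines without the ring carbonyl and both end at a limit, whereas compound 3 gives a true number, although this floor shows no change beyond the scatter. The step between compound 2 and compound 4 cannot be read, because both sit at the same limit: the limit of > 1 h in this assay, at which 2 of the 4 values shown sit.

Ring size, the ring carbonyl and the amide hydrogen all change together from compound 3 to compound 4, so their separate contributions remain open. A (1-methylpyrrolidin-3-yl)amino group, keeping the amide hydrogen, would separate the last of these from the other two.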